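Shortening the ester chain of compound 1

The source may report more compounds than this note shows. Statements on the series, on what has been measured and on what is new or still open speak of the compounds shown alone.

In a functional assay on HeLa cells (Homo sapiens) for antiproliferative activity, read by MTT assay, with a stated time of 72 h (on this read-out lower numbers stand for stronger inhibition and higher numbers for weaker inhibition), compound 1 (`CCCCCCCC(=O)Oc1cc(C(=O)C2=C3OC(C)(C)[C@@H](CC=C(C)C)C[C@@]34C[C@@H](CC=C(C)C)C(C)(C)[C@H]3CCC(C)(C)O[C@]34OC2=O)ccc1O`) reads > 20000 nM and that reading is a limit, not a number. Compound 1 therefore stands at the limit of > 20000 nM in this assay, at which 2 of the 3 values shown sit, and has no exact place in the series. Compound 3 (`CC(C)=CC[C@H]1C[C@]23C[C@@H](CC=C(C)C)C(C)(C)[C@H]4CCC(C)(C)O[C@]42OC(=O)C(C(=O)c2ccc(OC(=O)c4ccccc4)c(OC(=O)c4ccccc4)c2)=C3OC1(C)C`) gives > 20000 nM and that reading is also a limit. Going by the values given here, compound 2 (`CC(=O)Oc1ccc(C(=O)C2=C3OC(C)(C)[C@@H](CC=C(C)C)C[C@@]34C[C@@H](CC=C(C)C)C(C)(C)[C@H]3CCC(C)(C)O[C@]34OC2=O)cc1OC(C)=O`) gives 5320 nM as the only true number so far.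

Compound 4 (`CCCCCC(=O)Oc1cc(C(=O)C2=C3OC(C)(C)[C@@H](CC=C(C)C)C[C@@]34C[C@@H](CC=C(C)C)C(C)(C)[C@H]3CCC(C)(C)O[C@]34OC2=O)ccc1O`) differs from compound 1 in one place (hydrogen in place of ethyl on a saturated chain carbon, five bonds along the chain from a carbonyl carbon), with hydrogen in place of ethyl on a saturated chain carbon, five bonds along the chain from a carbonyl carbon. Among the compounds with values here, no pair of measured compounds shows this change, so any expectation rests on three quite different esters. In this assay only a small shift toward stronger inhibition is expected, and a second reading at the limit is about as likely as a number. The estimated size is an at least 1.1-fold lower number from compound 1 to compound 4 (0.04 log units; that floor lies within the scatter) and it can only be approximate. The reach of the range into measurable values rests on compound 2 at 5320 nM in the same series. Compound 4 is estimated at 18000 nM with an expected range from 7000 nM to 40000 nM for a single measurement.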

Compound 4, half-maximal inhibitory concentration: > 20000 nM
Compound 4 ended at the assay's limit (the forecaster's own chance of this, stated with the estimate: 50%); middle value at least 1.1-fold (0.04 log units) from the limit.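

In this assay compound 4 gives > 20000 nM as a limit, not a number. The step between compound 1 and compound 4 cannot be read, with both compounds at the same limit: the limit of > 20000 nM in this assay, at which 3 of the 4 values shown sit.

The compounds shown leave open how far compound 1 and compound 4 lie past that limit, and whether shortening the ester chain changes the activity at all.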